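This account rests on a few compounds, and the source may have more. Where it says the series, first, only, none or still open, it means among the compounds named here.

Measured so far in an assay on HEK293 cells for inhibition of solute carrier family 22 member 12 (Homo sapiens), read by scintillation counting, with a stated time of 12 min; a higher number here means a weaker inhibitor, a lower number a stronger inhibitor:
compound 1 `O=C(O)C1(Sc2ncnc3ccccc23)CCC1` gives > 10000 nM, a limit of the assay.
compound 2 `O=C(O)C1(Sc2nccc3ncccc23)CCC1` gives > 10000 nM, a limit of the assay.
compound 3 `O=C(O)C1(Sc2ccnc3ccc(O)cc23)CCC1` gives > 10000 nM, a limit of the assay.

Compound 3 therefore stands nowhere in particular on these numbers: it sits with the other two at the limit of > 10000 nM in this assay, at which 3 of the 3 values shown sit, and none of the three has given a number in this assay. Within the data shown here, no step between measured compounds can be worked out from this.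

Compound 4 `CNC(=O)COc1ccc2nccc(SC3(C(=O)O)CCC3)c2c1` differs from compound 3 by (methylcarbamoyl)methyl in place of hydrogen on an oxygen on an aromatic ring. With every shown value a limit, the size and direction of this step rest on nothing measured, and the expectation stays close to the limit. The step from compound 3 to compound 4 in this assay is estimated at an at least 1.2-fold lower number from compound 3 to compound 4 (0.09 log units; that floor lies within the scatter). Compound 4 is expected near 8000 nM, within a range of 1500 nM to 30000 nM.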

Compound 4, half-maximal inhibitory concentration: > 10000 nM
Compound 4: no number, only a limit; the forecaster's own chance of this, stated with the estimate: 60%; middle value at least 1.2-fold (0.09 log units) away from the limit.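

In this assay the step from compound 3 to compound 4 cannot be read, both values being limits: the limit of > 10000 nM in this assay, at which 4 of the 4 values shown sit.
The compounds shown leave open whether any change to the shared core gives a readable number in this assay at all.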